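The source may hold more compounds than are shown below. What is called first, only, known or untested is meant among the compounds shown, and "the series" means these compounds.

Compound 1 `Cc1cccc(NC(=O)Nc2cccc(CNc3ncnc4ccccc34)c2)c1` joins a urea bearing a 3-methylphenyl group to a benzylamine that hangs from its core. In a functional assay on HepG2 cells (Homo sapiens) for antiproliferative activity, read by MTT assay (a higher number here means a weaker inhibitor, a lower number a stronger inhibitor), compound 1 gives > 50000 nM, which is a limit of the assay rather than a number. Compound 2 `Cc1ccc(NC(=O)Nc2cccc(CNc3ncnc4ccccc34)c2)cc1` differs from compound 1 by 4-methylphenyl in place of 3-methylphenyl on an amide-type nitrogen. In this assay compound 2 likewise gives only a limit, > 50000 nM. The step that the two limits leave unreadable from compound 1 to compound 2 therefore has no readable size; it is hidden by the limit of > 50000 nM in this assay, at which 2 of the 3 values shown sit.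

Compound 3 `COc1cc2ncnc(NCc3cccc(NC(=O)Nc4cccc(C)c4)c3)c2cc1OC` is built on another core; the difference between the two cores is not broken down here. In this assay, within the data shown here, compound 3 gives 21500 nM, the one real number among the three values. Compound 4 `COc1cc2ncnc(NCc3cccc(NC(=O)Nc4ccc(C)cc4)c3)c2cc1OC`, not yet measured, differs from compound 3 by 4-methylphenyl in place of 3-methylphenyl on an amide-type nitrogen, the same change as from compound 1 to compound 2, at the same place. That earlier instance gave no measurable size, so the expectation rests on little more than the value of compound 3. Compound 4 is expected to give about 25000 nM in this assay. This corresponds to an expected step of a 1.2-fold higher number from compound 3 to compound 4 (0.07 log units; within the scatter), with a real chance that only a limit is returned.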

Compound 4, half-maximal inhibitory concentration: > 50000 nM
Compound 4: a limit, no number; the forecaster's own chance of this, stated with the estimate: 30%; middle value at least 2.0-fold (0.30 log units) away from the limit.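

On the core of compound 3, this assay shows an at least 2.3-fold higher number from compound 3 to compound 4 (0.36 log units; beyond the scatter) when the methyl group moves from 3-methylphenyl to 4-methylphenyl, so here the change gives a weaker inhibitor by more than the usual scatter. Compound 4 gives only a limit, > 50000 nM, so this step has a lower bound but no exact size. Among these compounds, it does not show that the change behaves the same way on both cores, since the matching step on the core of compound 1 cannot be read and only one instance remains: the limit of > 50000 nM in this assay, at which 3 of the 4 values shown sit.

With a single real number among the compounds shown, it remains open how the urea's aryl group can be changed to give a stronger inhibitor in this assay. A chlorine or methoxy group in place of the methyl, or an amine or carboxylic acid on that ring, might return a measurable value on either core, and such values could finally allow the two cores to be compared.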